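Adding Two Carbons While Cells Stay Tolerant

The compounds below may be only part of what the source reports. "The series", "measured", "known", "first", "only" and "open" are said of these compounds alone.

Compound 1 `CCOc1ccc(C(=O)NNc2c(Br)cccc2Br)cc1` and compound 2 `CCCCOc1ccc(C(=O)NNc2c(Br)cccc2Br)cc1` differ by ethyl in place of hydrogen on a saturated chain carbon, two bonds along the chain from an oxygen on an aromatic ring. In a toxicity assay on MDCK cells (Canis lupus familiaris) for cytotoxicity, read by CCK-8 assay, with a stated time of 48 h (a higher number here means that more compound is tolerated, a lower number that less compound is tolerated), compound 1 reaches only the limit > 100000 nM. Compound 2 likewise sits at a limit, > 100000 nM. The step that the two limits leave unreadable from compound 1 to compound 2 cannot be sized, since (the limit of > 100000 nM in this assay, at which 3 of the 3 values shown sit). Compound 3 `Cc1ccc(C(=O)NNc2c(Cl)cccc2Cl)cc1` is also at a limit: in this assay compound 3 gives > 100000 nM. How the core of compound 3 differs from that of compound 1 is not broken down here. Compound 4 `CCCc1ccc(C(=O)NNc2c(Cl)cccc2Cl)cc1` is not yet measured; it differs from compound 3 by ethyl in place of hydrogen on a saturated chain carbon bound to an aromatic carbon, the same kind of change as in the earlier pair, though the surroundings differ: there the saturated chain carbon lay two bonds along the chain from an oxygen on an aromatic ring, here it is bound to an aromatic carbon. Compound 4 is expected to stay at the limit, a step that the limit leaves unreadable from compound 3 to compound 4. This rests on compound 3 giving the limit > 100000 nM. Compound 4 is estimated at 150000 nM.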

Compound 4, half-maximal cytotoxic concentration: > 100000 nM
Compound 4: no number, only a limit; the forecaster's own chance of this, stated with the estimate: 85%; the middle value lies beyond the limit too.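

In this assay compound 4 gives > 100000 nM, which is a limit and not a number. The size of the change from compound 3 to compound 4 therefore cannot be read: the limit of > 100000 nM in this assay, at which 4 of the 4 values shown sit. The compounds shown leave open what concentration of any of them would harm these cells, and whether lengthening the chain changes it.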